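Swapping the benzylamino group on a quinazoline-type core

This account rests on a few compounds, and the source may have more. Where it says the series, first, only, none or still open, it means among the compounds named here.

Measured compounds:
Compound 1, `COc1cc2nc(NCc3ccccc3)nc(NC3CCCCCC3)c2cc1OC`: 13%
Compound 2, `COc1cc2nc(N3CCC(N4CCCC4)CC3)nc(NCc3ccccc3)c2cc1OC`: 10%

Both were tested in an in vitro functional assay on B300-19 cells for antagonist activity at C-C chemokine receptor type 4 (Homo sapiens), read by GTPgammaS binding, tested at 1 uM; on this read-out higher numbers stand for more inhibition at the one concentration tested (going by the name of the read-out) and lower numbers for less inhibition. There compound 1 gives 13% and compound 2 gives 10%; the gap between them is within the usual scatter, so neither stands apart. Compound 3, `COc1cc2nc(N3CCC(C(N)=O)CC3)nc(NC3CCCCCC3)c2cc1OC`, has not yet been measured. Compared with compound 1 it carries the change (4-carbamoylpiperidin-1-yl in place of benzylamino on an aromatic carbon). With only two weak, mutually indistinguishable values to go on, the step of a number 1 percentage points lower from compound 1 to compound 3 (within the scatter) is expected to be no larger than the scatter. Compound 3 is therefore estimated at 12%, within 0% to 35%.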

Compound 3, a percentage reported as inhibition, at one concentration (the size of the read-out at that concentration, not a potency): 17%
The estimate for compound 3 lay 5 percentage points below the measured number; the measured number falls inside the stated range.
By their numbers in this assay, from the lowest: compounds 2, 1 and 3 (each within the scatter of the next).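

In this assay, putting 4-carbamoylpiperidin-1-yl in place of benzylamino gives a number 4 percentage points higher from compound 1 to compound 3 (within the scatter). At this position between two ring nitrogen atoms, two quite different groups therefore cannot be told apart, and inhibition stays low with both. Nothing available explains this result.

From the compounds shown here alone, it remains open whether a carboxylic acid in place of the carbamoyl group, or a simple amine such as dimethylamino in place of the whole piperidine, would move inhibition beyond the scatter. Going by these compounds, whether any change at this position can do so also remains unknown.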